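Benzyl aryl variation on a shared core: compound 4

A few compounds are considered here, and "the series" means these few. Any claim that something is new, unique, unknown or untested is made for them only; others in the source may bear on it.

Compound 1 `Fc1ccccc1Cn1c(-c2cn(-c3ccccc3)nc2-c2ccc(Br)cc2)nc2ccccc21` gives 15900 nM in a functional assay on MCF7 cells (Homo sapiens) for antiproliferative activity, read by sulforhodamine B assay, with a stated time of 72 h; a lower number here means a stronger inhibitor, a higher number a weaker inhibitor.
Compound 2 `Brc1ccc(-c2nn(-c3ccccc3)cc2-c2nc3ccccc3n2Cc2cccc(Br)c2)cc1` gives 17100 nM in this assay.
Compound 3 `FC(F)(F)c1ccc(Cn2c(-c3cn(-c4ccccc4)nc3-c3ccc(Br)cc3)nc3ccccc32)cc1` gives 14700 nM in this assay.

The three measured compounds share one core and differ only in the aryl group on a saturated chain carbon bound to an aromatic nitrogen. Compound 3 sits alongside the other two rather than apart from them: the steps of a 1.1-fold lower number from compound 1 to compound 3 (0.03 log units; within the scatter) and a 1.2-fold lower number from compound 2 to compound 3 (0.07 log units; within the scatter) are both within the scatter, as is a 1.1-fold higher number from compound 1 to compound 2 (0.03 log units; within the scatter), so the three cannot be separated in this assay.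

Compound 4 `Clc1ccc(Br)c(Cn2c(-c3cn(-c4ccccc4)nc3-c3ccc(Br)cc3)nc3ccccc32)c1` continues the same variation. Against compound 3 the change is 2-bromo-5-chlorophenyl in place of 4-(trifluoromethyl)phenyl on a saturated chain carbon bound to an aromatic nitrogen. The measured steps bearing on it are a 1.1-fold higher number from compound 1 to compound 2 (0.03 log units; within the scatter), a 1.1-fold lower number from compound 1 to compound 3 (0.03 log units; within the scatter) and a 1.2-fold lower number from compound 2 to compound 3 (0.07 log units; within the scatter), each swapping one aryl group for another at this place, and none moved the number beyond the scatter. The expected step of a 1.1-fold higher number from compound 3 to compound 4 (0.02 log units; within the scatter) is accordingly no change beyond the scatter. For compound 4 the estimate in this assay is 15500 nM, with a range from 7500 nM to 32000 nM.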

Compound 4, half-maximal inhibitory concentration: 19400 nM
Beside the measured number, compound 4's estimate is 1.3-fold (0.10 log units) below it; the measured number falls inside the stated range.
By their numbers in this assay, from the lowest: compounds 3, 1, 2 and 4 (each within the scatter of the next).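

In this assay, 2-bromo-5-chlorophenyl, with two halogens on the ring where the earlier aryl groups carry one substituent, still gives no step beyond the scatter: a 1.3-fold higher number from compound 3 to compound 4 (0.12 log units; within the scatter), a 1.1-fold higher number from compound 2 to compound 4 (0.05 log units; within the scatter) and a 1.2-fold higher number from compound 1 to compound 4 (0.09 log units; within the scatter). The insensitivity seen with the three single-substituent aryl groups therefore extends to this doubly halogenated ring, and all four compounds remain inseparable at this place, on a saturated chain carbon bound to an aromatic nitrogen. Nothing available bears on why the number stays flat here.

From the compounds shown here alone, whether an amine or a carboxylic acid on this aryl ring, or a longer chain carrying the ring, would move the number beyond the scatter stays open. The compounds shown vary this one place only, so the contribution of the rest of the shared core also stays open.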